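Rearranging a Bicyclic Aromatic Group with Solubility at the Limit

The source may hold more compounds than are shown below. What is called first, only, known or untested is meant among the compounds shown, and "the series" means these compounds.

Compound 1 `CNC(=O)c1cc(C(=O)NC2CC2)cn(Cc2ccc3nc[nH]c3c2)c1=O` was tested in a physicochemical assay for solubility; a lower number here means a less soluble compound, a higher number a more soluble compound. In this assay compound 1 gives >= 163 ug/mL, which is a limit of the assay rather than a number. Compound 2 `CNC(=O)c1cc(C(=O)NCCOC)cn(Cc2ccccc2)c1=O` carries a different amide side chain and a plain benzyl group. In this assay compound 2 gives >= 164 ug/mL, again a limit and not a number. Compound 1 thus stands at the ceiling of what this assay can report, and nothing sets it apart from compound 2.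

Compound 3 `CNC(=O)c1cc(C(=O)NC2CC2)cn(Cc2nccc3[nH]ccc23)c1=O` awaits measurement. It differs from compound 1 in one place: a group of 9 heavy atoms (7 carbon, 2 nitrogen; one five-membered aromatic ring with 1 hetero atom, one six-membered aromatic ring with 1 hetero atom) in place of a group of 9 heavy atoms (7 carbon, 2 nitrogen; one five-membered aromatic ring with 2 hetero atoms, one six-membered aromatic ring of carbon only), on a saturated chain carbon bound to an aromatic nitrogen. The two groups have the same atoms, joined differently. Among the measured compounds shown here, no measured step shows how such a change moves this assay; the step of an at least 1.0-fold lower number from compound 1 to compound 3 (0.00 log units; that floor lies within the scatter) is expected to be none beyond the scatter. Compound 3 is expected to give 160 ug/mL, between 60 ug/mL and 320 ug/mL, most likely again reported as a limit.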

Compound 3, solubility: 73 ug/mL
Compound 3: middle estimate off by 2.2-fold (0.34 log units), on the high side; the range from low to high includes it.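

Compound 3 gives a true number in this assay where compounds 1 and 2 gave only limits, so the group on the saturated chain carbon bound to an aromatic nitrogen can move this read-out. The same atoms joined differently give an at least 2.2-fold lower number from compound 1 to compound 3 (0.34 log units; beyond the scatter) with the core and the amide side chains unchanged. The 1H-benzimidazol-6-yl group and the group that replaces it have the same counts of hydrogen-bond donors and acceptors and no net charge, so those counts alone do not account for the step.

As far as these compounds go, the true size of the step remains open because the value of compound 1 is a limit: the limit of >= 163 ug/mL in this assay, at which 1 of the 3 values shown sits. Also open, from the compounds shown here alone, are which feature of the rearranged group carries the step and whether an added amine or carboxylic acid on that group would change the number.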